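A few compounds are considered here, and "the series" means these few. Any claim that something is new, unique, unknown or untested is made for them only; others in the source may bear on it.

Among the compounds with values here, compound 2, whose structure is `Cc1ccc2ncc(S(=O)(=O)c3ccc(Cl)cc3)c(N3CCC(C)CC3)c2c1`, stands highest of the two numbers so far in an assay on isolated protein for displacement of a labelled ligand from metabotropic glutamate receptor 5 (Homo sapiens), with a stated time of 60 min, tested at 1 uM (on this read-out lower numbers stand for less inhibition and higher numbers for more inhibition at the one concentration tested (going by the name of the read-out)), where compound 2 gives 79%. Within the data shown here, the only other measured compound is compound 1, with the structure `COc1ccc(S(=O)(=O)c2cnc3ccc(C)cc3c2N2CCC(C)CC2)cc1`; in this assay compound 1 gives 62%. Among the measured compounds shown here, the single measured step, a number 17 percentage points higher from compound 1 to compound 2 (beyond the scatter), came from exchanging a methoxy group for a chlorine on the aromatic carbon of the sulfonyl-bearing ring.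

The unmeasured compound 3 has the structure `Cc1ccc2ncc(S(=O)(=O)c3cccc(Cl)c3)c(N3CCC(C)CC3)c2c1`. It differs from compound 2 in one place: 3-chlorophenyl in place of 4-chlorophenyl on a sulfonyl sulfur. For the measured compounds named here, the measured step from compound 1 to compound 2 concerns which group sits on that ring, not where the chlorine sits, so it does not bear directly on this change; no measured step does. Without a guiding step, the estimate for compound 3 is anchored to compound 2 and widened, and the expected step of a number 9 percentage points lower from compound 2 to compound 3 (within the scatter) is one that could fall within the scatter in either direction. Compound 3 is therefore estimated to give 70% in this assay, within a range from 48% to 88%.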

Compound 3, a percentage reported as inhibition, at one concentration (the size of the read-out at that concentration, not a potency): 91%
Compound 3: middle estimate off by 21 percentage points, on the low side; measured number above the stated range.
By their numbers in this assay, from the lowest: compound 1; then compound 2; then compound 3.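

In this assay, the position of the chlorine on the ring carried by the sulfonyl sulfur proves to matter as well as its presence: 3-chlorophenyl in place of 4-chlorophenyl gives a number 12 percentage points higher from compound 2 to compound 3 (beyond the scatter), a change with no atoms gained or lost. Set against the 4-methoxyphenyl group, 3-chlorophenyl gives a number 29 percentage points higher from compound 1 to compound 3 (beyond the scatter), which places compound 3 highest of the three, with its steps to both others beyond the scatter. Nothing measured on these compounds accounts for the difference between the two chlorophenyl groups.

The compounds shown cannot separate the contribution of the chlorine from that of its place on the ring, since 3-methoxyphenyl, which would pair directly with both compound 1 and compound 3, does not appear among them, and neither do plain phenyl, 3-fluorophenyl or a phenyl ring bearing a nitrile. Going by these compounds, it also remains open how these differences at a single concentration would translate into potency, and whether the order of the three compounds would hold in a full concentration series.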